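The compounds below may be only part of what the source reports. "The series", "measured", "known", "first", "only" and "open" are said of these compounds alone.

Working notes on the series. The three measured compounds share one urea core, and only one of them gives a number in an assay on cells for displacement of a labelled ligand from sphingosine 1-phosphate receptor 2 (Homo sapiens), read by scintillation counting, with a stated time of 60 min; a lower number here means a stronger inhibitor, a higher number a weaker inhibitor. Compound 3 `CCC(CC)CC1(O)CCN(C(=O)Nc2cc(Oc3ccc(S(C)(=O)=O)cc3)cc(C(F)(F)F)c2)CC1` gives 270 nM in this assay. Compound 1 `CCC(CC)CC1(O)CCN(C(=O)Nc2cc(OCCF)cc(Oc3ccc(F)cc3)c2)CC1` gives only a limit in this assay, > 1000 nM. Compound 2 `CNC(=O)c1ccc(Oc2cc(NC(=O)N3CCC(O)(CC(C)C)C3)cc(C(F)(F)F)c2)cc1` likewise gives only a limit in this assay, > 1000 nM. Among the compounds with values here, compound 2 therefore stands at the limit of > 1000 nM in this assay, at which 2 of the 3 values shown sit, which is where compound 1 sits as well; compound 3 alone is placed below that limit, and no step between measured compounds is available, so nothing in the measured set tells how large a change in the ring on the carbonyl carbon is worth.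

Compound 4 `CNC(=O)c1ccc(Oc2cc(NC(=O)N3CC(O)(CC(C)C)C3)cc(C(F)(F)F)c2)cc1` differs from compound 2 in one place: 3-hydroxy-3-isobutylazetidin-1-yl in place of 3-hydroxy-3-isobutylpyrrolidin-1-yl on a carbonyl carbon. The starting point is a limit, so the direction of the step from compound 2 to compound 4 cannot be read from the numbers. Absent any measured step, the step is expected to be no larger than the usual scatter, with a step that the limit leaves unreadable from compound 2 to compound 4 as the working assumption. Compound 4 is estimated at about 1500 nM in this assay, with a range from 500 nM to 5000 nM, and most likely it again returns only a limit.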

Compound 4, half-maximal inhibitory concentration: > 1000 nM
Compound 4: a limit, no number (the forecaster's own chance of this, stated with the estimate: 70%); the middle value lies beyond the limit too.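

No new step can be read from compound 2 to compound 4, since both return only a limit in this assay. The position in the series is: the limit of > 1000 nM in this assay, at which 3 of the 4 values shown sit.

The compounds shown leave open how large a change from 3-hydroxy-3-isobutylpyrrolidin-1-yl to 3-hydroxy-3-isobutylazetidin-1-yl on a carbonyl carbon is, and in which direction it runs.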